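Chloro for Methyl on the Benzyl Ring

The source may hold more compounds than are shown below. What is called first, only, known or untested is meant among the compounds shown, and "the series" means these compounds.

Of the compounds shown here, three sharing one core have been tested in a functional assay on HeLa cells (Homo sapiens) for cytotoxicity, read by MTT assay, with a stated time of 24 h; on this read-out higher numbers stand for weaker inhibition and lower numbers for stronger inhibition. Compound 1 `C=CC1=C(C(=O)NCc2ccc(C)cc2)C(c2ccc(OC)cc2)OC1` gives 15900 nM. Compound 2 `C=CC1=C(C(=O)NCc2ccc(C)cc2)C(c2ccc(F)cc2)OC1` reaches only the limit of the assay, > 100000 nM. Compound 3 `C=CC1=C(C(=O)Nc2ccc(OCC)cc2)C(c2ccc(F)cc2)OC1` also shows only a limit, > 100000 nM. Among the measured compounds shown here, the single measured step, an at least 6.2-fold higher number from compound 1 to compound 2 (0.79 log units; beyond the scatter), concerns the other ring and not the change considered here. Compound 2 therefore stands at the limit of > 100000 nM in this assay, at which 2 of the 3 values shown sit, so no number is known for it. The unmeasured compound 4 `C=CC1=C(C(=O)NCc2ccc(Cl)cc2)C(c2ccc(F)cc2)OC1` differs from compound 2 by chloro in place of methyl on an aromatic carbon. For the measured compounds named here, no measured step bears on this change, so nothing beyond the scatter is expected, and the estimated step is a number no higher from compound 2 to compound 4 (the limit leaves the size open). Compound 4 is estimated at 100000 nM, within a range from 30000 nM to 300000 nM.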

Compound 4, half-maximal inhibitory concentration: > 100000 nM
Compound 4 was reported as a limit; the forecaster's own chance of this, stated with the estimate: 70%; the middle value lies on the limit itself.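

Among the compounds shown here, compound 2 and compound 4 both show only a limit in this assay, not a number, so no step between them can be read. The compounds shown leave open whether 4-chlorobenzyl and 4-methylbenzyl differ at all here.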